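The source may hold more compounds than are shown below. What is called first, only, known or untested is meant among the compounds shown, and "the series" means these compounds.

Compound 1 `Cc1ccc2[nH]c(=O)c(-c3nc4cc(C)c(C)cc4[nH]3)cc2c1` and compound 3 `Cc1cc2nc(-c3cc4ccccc4[nH]c3=O)[nH]c2cc1C` are built on one core, while compound 2 `Cc1ccc2[nH]c(=O)c(-c3nc4cc(Cl)ccc4[nH]3)cc2c1` and the as yet unmeasured compound 4 `O=c1[nH]c2ccccc2cc1-c1nc2cc(Cl)ccc2[nH]1` are built on another; the difference between the two cores is not broken down here. Within the data shown here, in a functional assay on BEL-7404 cells for cytotoxicity against BEL-7404 tumor cell line (Homo sapiens), read by MTT assay, with a stated time of 48 h (on this read-out higher numbers stand for weaker inhibition and lower numbers for stronger inhibition), compound 2 gives 39000 nM, the only value here that is a number rather than a limit. Compound 1 reaches only a limit of the assay, > 100000 nM. Compound 3 likewise reaches only a limit, > 100000 nM. Compound 3 arises from compound 1 by hydrogen in place of methyl on an aromatic carbon, and the step that the two limits leave unreadable from compound 1 to compound 3 cannot be read because both values sit at the limit of > 100000 nM in this assay, at which 2 of the 3 values shown sit. Compound 4 arises from compound 2 by the same change, (hydrogen in place of methyl on an aromatic carbon). Among the measured compounds shown here, the one measured example of this change thus says nothing about how large it is, and no other measured step here points to a large shift in either direction. The step of a 1.3-fold higher number from compound 2 to compound 4 (0.11 log units; within the scatter) is expected to be small. Compound 4 is therefore estimated at 50000 nM in this assay, most likely between 15000 nM and 150000 nM. For compound 4 there is also a fair chance that the assay reports only a limit, as it did for compound 1 and compound 3, rather than a number.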

Compound 4, half-maximal inhibitory concentration: 16500 nM
Beside the measured number, compound 4's estimate is 3.0-fold (0.48 log units) above it; low and high end bracket the measured number.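

In this assay, replacing the methyl on an aromatic carbon with hydrogen is a 2.4-fold lower number from compound 2 to compound 4 (0.37 log units; beyond the scatter), so on this core the change brings a modest gain in inhibition that goes beyond the usual scatter. The same change on the core of compound 1, from compound 1 to compound 3, cannot be read, because both compounds give a limit of the assay rather than a number: the limit of > 100000 nM in this assay, at which 2 of the 4 values shown sit. The change therefore has a measured size on one core only, and this single pair shows neither that the gain carries over to the other core nor that it fails to do so.

Among the compounds shown, this place on the ring carries only methyl or hydrogen, so it remains open what an amine, a methoxy group or a longer chain such as propyl would do there. Also open, from the compounds shown here alone, is whether an analogue on the core of compound 1 could give a real number in this assay, which would allow the change to be compared on both cores.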